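A few compounds are considered here, and "the series" means these few. Any claim that something is new, unique, unknown or untested is made for them only; others in the source may bear on it.

Compound 1 `Cc1cc(C(=O)O)nn1-c1ccc(S(=O)(=O)NC(=S)NCc2ccccc2)cc1` — in a functional assay on the whole organism (blood, strain albino) with Mus musculus as the target, with stated times of 6 days and 4 h, at a dose of 0.4 mmol/kg by the oral route (a higher number here means more inhibition at the dose given (going by the name of the read-out), a lower number less inhibition), compound 1 gives < 2%, which is a limit of the assay and not a number.
Compound 2 `C=CCNC(=S)NS(=O)(=O)c1ccc(-n2nc(C(=O)O)cc2C)cc1` — in this assay compound 2 gives -6%.

Compound 2 holds the only number shown here; the other value is a limit (the limit of < 2% in this assay, at which 1 of the 2 values shown sits). The step that the limit leaves unreadable from compound 1 to compound 2 cannot be read in size. Compound 3 `CCCNC(=S)NS(=O)(=O)c1ccc(-n2nc(C(=O)O)cc2C)cc1` differs from compound 2 by ethyl in place of vinyl on a saturated chain carbon bound to an amide-type nitrogen. No readable measured step bears on this change. The expected step is a number 2 percentage points higher from compound 2 to compound 3 (within the scatter), within the scatter. Compound 3 is estimated at -4%, with a range from -16% to 8%.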

Compound 3, a percentage reported as inhibition, in the whole organism at one dose (the size of the read-out at that dose, not a potency): < 1%
Compound 3 was reported as a limit (the forecaster's own chance of this, stated with the estimate: 40%); the middle value is on the limit's open side.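

Compound 3 is reported only as a limit of the assay, and its steps from compound 1 and from compound 2 cannot be read in size. The compounds shown leave open whether ethyl in place of vinyl or phenyl shifts the inhibition in this assay at all.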